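Swapping the bromobenzyl sulfide for a phenethyl sulfide

The source may hold more compounds than are shown below. What is called first, only, known or untested is meant among the compounds shown, and "the series" means these compounds.

Measured compounds:
- Compound 1, `O=[N+]([O-])c1ccc2c(c1)CN(c1ncnc3c1ncn3[C@@H]1O[C@H](CO)[C@@H](O)[C@H]1O)CC2`: 5.5 nM
- Compound 2, `OC[C@H]1O[C@@H](n2cnc3c(SCC4CCCCC4)ncnc32)[C@H](O)[C@@H]1O`: 1550 nM
- Compound 3, `Nc1nc(SCc2ccc(Br)cc2)c2ncn([C@@H]3O[C@H](CO)[C@@H](O)[C@H]3O)c2n1`: 813 nM

The three measured compounds share the same sugar-bearing core and were all tested in an assay on isolated protein for binding affinity to Equilibrative nucleoside transporter 1 (Homo sapiens); a higher number here means a weaker inhibitor, a lower number a stronger inhibitor. Compound 1 gives 5.5 nM and stands far from the other two. Compound 3 gives 813 nM, the second highest of the three numbers; the gap to compound 1 lies well beyond the usual scatter, while the gap to compound 2, which gives 1550 nM, lies within it, so these two cannot be told apart.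

Compound 4, `Nc1nc(SCCc2ccccc2)c2ncn([C@@H]3O[C@H](CO)[C@@H](O)[C@H]3O)c2n1`, differs from compound 3 in one place: benzyl in place of 4-bromophenyl on a saturated chain carbon bound to a sulfur. Cut one bond further out, the change reads 4-bromobenzyl to phenethyl. For the measured compounds named here, no measured pair shows this change, so its effect is unknown here. A modest step toward a somewhat higher number is expected, as a 1.5-fold higher number from compound 3 to compound 4 (0.17 log units; within the scatter), though a step within the scatter is just as plausible. In this assay compound 4 is expected to give about 1200 nM, estimated to fall between 300 nM and 5000 nM.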

Compound 4, half-maximal inhibitory concentration: 16200 nM
Beside the measured number, compound 4's estimate is 14-fold (1.13 log units) below it; the whole stated range lies below it.
By their numbers in this assay, from the lowest: compound 1; then compounds 3 and 2 (each within the scatter of the next); then compound 4.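

In this assay, the change from 4-bromobenzyl to phenethyl on the sulfur gives a 20-fold higher number from compound 3 to compound 4 (1.30 log units; beyond the scatter), so this position responds strongly even though the groups that leave and enter each carry one six-membered aromatic ring of carbon only. Two things differ in this one step: the bromine is lost and the chain carrying the ring lengthens, and the step alone cannot separate them. Nothing available here accounts for a step of this size.

Still open, as far as these compounds go, is whether the bromine or the chain length matters more, which a plain benzyl sulfide or a 4-bromophenethyl sulfide on the same core could help to settle. Also open, from the compounds shown here alone, is how a longer chain on the sulfur, or an amine in place of the sulfur, would behave.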